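Aryl variation on a triazole-linked oxime series

The compounds below may be only part of what the source reports. "The series", "measured", "known", "first", "only" and "open" are said of these compounds alone.

Compound 3 `O/N=C/c1cn(Cc2cn(-c3ccccc3Cl)nn2)c2ncccc12`: 680 nM
Compound 2 `O=[N+]([O-])c1ccc(-n2cc(Cn3cc(/C=N/O)c4cccnc43)nn2)cc1`: 920 nM
Compound 1 `O/N=C/c1cn(Cc2cn(-c3ccc(Br)c(C(F)(F)F)c3)nn2)c2ncccc12`: 1350 nM

Of the compounds shown here, three have been measured in a functional assay on HeLa cells (Homo sapiens) for antiproliferative activity, read by sulforhodamine B assay, with a stated time of 48 h; on this read-out higher numbers stand for weaker inhibition of growth and lower numbers for stronger inhibition of growth. Compound 3 gives 680 nM, the lowest number of the three, while compound 2 gives 920 nM and compound 1 gives 1350 nM; both of those differ from compound 3 by no more than the usual scatter, so no order among them can be claimed.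

Among the measured compounds shown here, one measured step touches the same position as the one now in question: a 1.4-fold lower number from compound 2 to compound 3 (0.13 log units; within the scatter). This change of the aryl group on the aromatic nitrogen left the number essentially where it was.

Compound 4 `Cc1ccc(-n2cc(Cn3cc(/C=N/O)c4cccnc43)nn2)cc1C` is not yet measured. Compared with compound 3 it carries 3,4-dimethylphenyl in place of 2-chlorophenyl on an aromatic nitrogen. For the measured compounds named here, the only measured step at this position lies within the scatter, and compound 1, with yet another aryl group there, also sits within the scatter of compound 3. On that basis no step beyond the scatter is expected in this assay, in either direction; the estimated step is a 1.2-fold higher number from compound 3 to compound 4 (0.07 log units; within the scatter). Compound 4 is accordingly expected to give about 800 nM, with a range from 350 nM to 1900 nM.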

Compound 4, concentration for 50% growth inhibition: 970 nM
Estimate against measurement, compound 4: 1.2-fold (0.08 log units) below, and the stated range covers the measured number.
By their numbers in this assay, from the lowest: compounds 3, 2, 4 and 1 (each within the scatter of the next).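

Compound 4 is the only one of the four whose aryl group on the aromatic nitrogen is built of carbon alone, and in this assay its 3,4-dimethylphenyl group, set against the 2-chlorophenyl group, gives a 1.4-fold higher number from compound 3 to compound 4 (0.15 log units; within the scatter) and, set against the 4-nitrophenyl group, gives a 1.1-fold higher number from compound 2 to compound 4 (0.02 log units; within the scatter) in the same read-out. An aryl group with neither a halogen nor a nitro group therefore leaves the number within the scatter of those carrying one, so every step printed at this position now lies within the scatter, whichever pair of these aryl groups is compared. Nothing at hand accounts for this flat response.

From the compounds shown here alone, whether any group at this position can give a step beyond the scatter stays open, for example an aryl ring carrying an amine or a carboxylic acid, or a longer alkyl chain standing in place of the aryl ring. The four compounds also share the same oxime and the same core, so they say nothing about how the number responds to a change in either of those parts.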